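This account rests on a few compounds, and the source may have more. Where it says the series, first, only, none or still open, it means among the compounds named here.

Compound 1, `N=C(N)c1ccc(-c2ccc(-c3ccc(F)cc3)o2)o1`: 490 nM
Compound 2, `N=C(N)c1ccc(-c2ccc(-c3ccc(Cl)cc3)s2)s1`: 670 nM
Compound 3, `N=C(N)c1ccc(-c2ccc(-c3ccc4ccccc4c3)s2)s1`: 1530 nM

All three were tested in a functional assay on K562 cells (Homo sapiens) for inhibition, read by sulforhodamine B assay, with a stated time of 48 h; a higher number here means a weaker inhibitor of growth, a lower number a stronger inhibitor of growth. Among them compound 1 gives the lowest number. Compound 2 stands closest to it, and the two values lie within the usual scatter of each other, so no order can be set between them. Compound 3 gives a number further from that of compound 1, and that gap lies beyond the scatter. Within the data shown here, no pair of these measured compounds differs in one place only, so no single-point step can be read from them.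

Compound 4, `COc1ccc(-c2ccc(-c3ccc(C(=N)N)o3)o2)cc1`, is not yet measured in this assay. It differs from compound 1 in one place: methoxy in place of fluoro on an aromatic carbon. Among the measured compounds shown here, nothing among the measured compounds shows what this change does. The expected step is a 1.2-fold higher number from compound 1 to compound 4 (0.09 log units; within the scatter), of no clear direction and not beyond the scatter. The estimate for compound 4 in this assay is 600 nM, with a range from 250 nM to 1500 nM.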

Compound 4, concentration for 50% growth inhibition: 490 nM
For compound 4 the middle estimate is 1.2-fold (0.09 log units) above the measured one; low and high end bracket the measured number.
By their numbers in this assay, from the lowest: compounds 1, 4 and 2 (each within the scatter of the next); then compound 3.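

In this assay the step is no change at the digits printed from compound 1 to compound 4 (within the scatter) when methoxy takes the place of fluoro on an aromatic carbon, para to a large group. Among these compounds, this is the first single-place step in the set, and it shows that at this position the two heavy atoms of methoxy, with its hydrogen-bond acceptor, can replace the single fluorine without a readable change in growth inhibition. No measurement shown gives a reason for this result.

Going by these compounds, whether an amine, a carboxylic acid or a longer chain such as butoxy at this position would leave the number equally unchanged remains open. Compounds 2 and 3 differ from compound 1 in more than one place, so their steps cannot be read, and the separate effects of their changes remain unresolved.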